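A few compounds are considered here, and "the series" means these few. Any claim that something is new, unique, unknown or untested is made for them only; others in the source may bear on it.

Measured so far in a functional assay on FTC-133 cells (Homo sapiens) for cytotoxicity, read by MTT assay, with a stated time of 24 h; on this read-out lower numbers stand for stronger inhibition and higher numbers for weaker inhibition:
compound 1 `CN1O[C@@H](n2cc(-c3ccccc3)nn2)C[C@@H]1CO` gives 6030 nM
compound 2 `CN1O[C@@H](n2ccnn2)C[C@@H]1CO` gives 6530 nM

Compound 1 has the lower of the two numbers shown, but the step of a 1.1-fold higher number from compound 1 to compound 2 (0.03 log units; within the scatter) is within the scatter, so the two values cannot be ordered. That step, hydrogen in place of phenyl on an aromatic carbon, is the only measured one that bears on the next change; it shows that the whole phenyl can be removed without a shift beyond the scatter in this assay.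

Compound 3 `COc1ccc(-c2cn([C@H]3C[C@H](CO)N(C)O3)nn2)cc1` is not yet measured. It differs from compound 1 by methoxy in place of hydrogen on an aromatic carbon, a small addition on the same phenyl whose complete removal left the number unchanged. Going by the values given here, no measured step shows what a substituent on that ring does, so the expectation rests on a 1.1-fold higher number from compound 1 to compound 2 (0.03 log units; within the scatter) alone. The expected step is a 1.0-fold lower number from compound 1 to compound 3 (0.00 log units; within the scatter), that is, none beyond the scatter in either direction. Compound 3 is accordingly estimated at 6000 nM, with a range of 2500 nM to 14000 nM.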

Compound 3, half-maximal inhibitory concentration: 7000 nM
Compound 3: middle estimate off by 1.2-fold (0.07 log units), on the low side; the range from low to high includes it.
By their numbers in this assay, from the lowest: compounds 1, 2 and 3 (each within the scatter of the next).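

In this assay methoxy in place of hydrogen, on an aromatic carbon para to a large group, gives a 1.2-fold higher number from compound 1 to compound 3 (0.06 log units; within the scatter) and so stays within the scatter. Going by these compounds alone, this is the first measured step for a substituent on the phenyl rather than removal of the whole ring. Both measured changes to the phenyl of compound 1, its removal and this methoxy addition, now leave the number within the scatter, and nothing available bears on why this is so.

Still open, as far as these compounds go, is whether a different group at this para place, such as an amine, a carboxylic acid or a longer alkoxy chain, would produce a step beyond the scatter. Also open, from the compounds shown here alone, is whether methoxy on another aromatic carbon of the phenyl, or a change on the shared core, would do so.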